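Adding a 4-fluorobenzyl Group to Compound 2

A few compounds are considered here, and "the series" means these few. Any claim that something is new, unique, unknown or untested is made for them only; others in the source may bear on it.

Two measured compounds share one core and differ in a single substituent. Compound 1 `Cc1ccc(NC(=S)N/N=C2\C(=O)Nc3ccc(Br)cc32)cc1` carries a bromo group, and in a functional assay on L1210 cells (Mus musculus), with a stated time of 48 h (a lower number here means a stronger inhibitor, a higher number a weaker inhibitor), compound 1 gives 9600 nM. Compound 2 `Cc1ccc(NC(=S)N/N=C2\C(=O)Nc3ccc(F)cc32)cc1` has fluoro in its place, and in this assay compound 2 gives 8200 nM. The step of a 1.2-fold lower number from compound 1 to compound 2 (0.07 log units; within the scatter) lies within the scatter, so the two cannot be ordered; compound 2 merely holds the lower of the two numbers, with compound 1 close beside it.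

Compound 3 `Cc1ccc(NC(=S)N/N=C2\C(=O)N(Cc3ccc(F)cc3)c3ccc(F)cc32)cc1` has not yet been measured. It differs from compound 2 by 4-fluorobenzyl in place of hydrogen on an amide-type nitrogen in a ring. For the measured compounds named here, no measured step bears on this change: the only step recorded, bromo to fluoro on the aromatic carbon, touches a different part of the core and stayed within the scatter. The expectation for compound 3 therefore rests on compound 2 alone. The step from compound 2 to compound 3 is estimated at a 1.6-fold lower number from compound 2 to compound 3 (0.21 log units; within the scatter), with no direction that can be called firm. In this assay compound 3 is expected to give about 5000 nM, within a range from 1500 nM to 20000 nM.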

Compound 3, half-maximal inhibitory concentration: 6200 nM
The estimate for compound 3 lay 1.2-fold (0.09 log units) below the measured number; low and high end bracket the measured number.
By their numbers in this assay, from the lowest: compounds 3, 2 and 1 (each within the scatter of the next).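

At the amide-type nitrogen in the ring, where compound 2 carries the amide hydrogen, compound 3 carries a 4-fluorobenzyl group, and in this assay this change gives a 1.3-fold lower number from compound 2 to compound 3 (0.12 log units; within the scatter). For the compounds shown here, this is the first reading at this position, which the earlier bromo-to-fluoro step on the aromatic carbon did not touch, and it shows that a group with a six-membered aromatic ring can stand on this nitrogen with no change in the number that can be told from the scatter. No evidence is at hand that would account for this result.

The compounds shown leave open whether any other group on this nitrogen, such as a methyl, an unsubstituted benzyl or a longer chain ending in an amine or a carboxylic acid, would move the number beyond the scatter. They also leave open whether the 4-fluorobenzyl group would give a similar number on the core of compound 1, with bromo in place of fluoro on the aromatic carbon.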